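Removing the sulfonamide from the indane-imidazole core

The compounds below may be only part of what the source reports. "The series", "measured", "known", "first", "only" and "open" are said of these compounds alone.

Compound 2 `CCCS(=O)(=O)Nc1cccc2c1CCC2c1ncc[nH]1` gives 1340 nM in a functional assay on CHO cells for agonist activity at Alpha-1A adrenergic receptor (Homo sapiens), read by FLIPR and calcium flux (on this read-out lower numbers stand for an effect already at smaller amounts and higher numbers for an effect only at larger amounts of compound), the highest of the three numbers at hand. Compound 1 `COc1c(C)ccc2c1CCC2c1ncc[nH]1` gives 167 nM in this assay, and compound 3 `Cc1c(OCC2=NCCN2)ccc(Cl)c1NS(C)(=O)=O` gives 25 nM; both gaps to compound 2 lie beyond the scatter. Compound 4 `c1ccc2c(c1)CCC2c1ncc[nH]1` is the unmeasured member: the change from compound 2 is hydrogen in place of (propylsulfonyl)amino on an aromatic carbon, leaving the bare core with its imidazole. Among the measured compounds shown here, no directly comparable pair is measured. Since compound 1, a substituted form of the same core, gives 167 nM, a step toward lower numbers from compound 2 to compound 4 is expected, a 3.4-fold lower number from compound 2 to compound 4 (0.53 log units; beyond the scatter), though its size is uncertain. Compound 4 is estimated at 400 nM, within 100 nM to 1600 nM.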

Compound 4, half-maximal effective concentration: 473 nM
The estimate for compound 4 lay 1.2-fold (0.07 log units) below the measured number; the measured number falls inside the stated range.
By their numbers in this assay, from the lowest: compound 3; then compound 1; then compound 4; then compound 2.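

In this assay, hydrogen in place of (propylsulfonyl)amino on an aromatic carbon gives a 2.8-fold lower number from compound 2 to compound 4 (0.45 log units; beyond the scatter) and so shows that the effect persists without this group. Among the compounds shown here, at this position, the (propylsulfonyl)amino group therefore carries a modest penalty relative to hydrogen, a comparison the earlier compounds could not offer. Nothing at hand explains the step. The compounds shown leave open whether a free amine or a longer chain on the sulfonyl group at this aromatic carbon would give a lower or higher number than hydrogen.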